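A few compounds are considered here, and "the series" means these few. Any claim that something is new, unique, unknown or untested is made for them only; others in the source may bear on it.

Measured compounds, with values in a functional assay on CEM-DNR-bulk cells (Homo sapiens), read by MTT assay, with a stated time of 72 h (on this read-out lower numbers stand for stronger inhibition and higher numbers for weaker inhibition), as follows
- compound 1 `Cc1nc(N)c2c(-c3ccco3)cn([C@@H]3O[C@H](CO)[C@@H](O)[C@H]3O)c2n1` gives > 20000 nM
- compound 2 `Cc1nc(N)c2c(-c3cccs3)cn([C@@H]3O[C@H](CO)[C@@H](O)[C@H]3O)c2n1` gives > 20000 nM
- compound 3 `Cc1nc(N)c2c(-c3ccccc3)cn([C@@H]3O[C@H](CO)[C@@H](O)[C@H]3O)c2n1` gives > 20000 nM

All three entries are limits of the assay and not numbers.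

Compound 3 has only a limit in this assay, namely > 20000 nM. It therefore has no numerical place in the series, and the same holds for the other two compounds: the limit of > 20000 nM in this assay, at which 3 of the 3 values shown sit.

The next change leads to compound 4 `Cc1nc(N)c2c(-c3cc4ccccc4o3)cn([C@@H]3O[C@H](CO)[C@@H](O)[C@H]3O)c2n1`, which carries 1-benzofuran-2-yl in place of phenyl on an aromatic carbon.

The measured steps that bear on this are the other swaps of the same substituent: a step that the two limits leave unreadable from compound 1 to compound 3, a step that the two limits leave unreadable from compound 2 to compound 3 and a step that the two limits leave unreadable from compound 1 to compound 2. None of them has a readable size, so they offer no measured trend to carry forward. They show only that furan-2-yl, thiophen-2-yl and phenyl all leave the shared core at the limit.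

The larger substituent is new to the series, so some uncertainty remains, and the most likely result is expected to be another limit. The expected step is a number no higher from compound 3 to compound 4 (the limit leaves the size open), with no direction expected beyond the scatter. Compound 4 is estimated at 20000 nM, with an expected range of 8000 nM to 40000 nM.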

Compound 4, half-maximal inhibitory concentration: 6310 nM
Estimate against measurement, compound 4: 3.2-fold (0.50 log units) above, and the stated range ends above it.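

In this assay, 1-benzofuran-2-yl is the only group shown at this position that gives a number rather than a limit, with an at least 3.1-fold lower number from compound 3 to compound 4 (0.50 log units; beyond the scatter) for the change from phenyl, an at least 3.1-fold lower number from compound 2 to compound 4 (0.50 log units; beyond the scatter) from thiophen-2-yl and an at least 3.1-fold lower number from compound 1 to compound 4 (0.50 log units; beyond the scatter) from furan-2-yl. Each of these steps starts from a limit, so it fixes a direction and a minimum size only, while the steps among the three earlier compounds cannot be read. The position is thus shown to respond to its substituent, since a fused pair of aromatic rings reaches a measurable value where the single five-membered and six-membered aromatic rings shown do not, and the remaining compounds stay at a limit: the limit of > 20000 nM in this assay, at which 3 of the 4 values shown sit.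

The compounds shown do not separate the part played by the second ring from that played by the ring oxygen of 1-benzofuran-2-yl, and a comparison with naphthalen-2-yl or 1-benzothiophen-2-yl would bear on this. They also leave open how far the value would move with an amine or a carboxylic acid on the fused rings.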